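From a bromophenyl to a methoxyphenyl on the shared core

The source may report more compounds than this note shows. Statements on the series, on what has been measured and on what is new or still open speak of the compounds shown alone.

Compound 1 `C=C1C(=O)[C@]23C[C@@]1(O)CC[C@H]2c1ccc(OS(=O)(=O)c2ccc(C)cc2)c(C)c1[C@@H]3Cn1cc(-c2ccc(Br)cc2)nn1` carries a (4-methylphenyl)sulfonyl on the phenolic oxygen of its core and a 4-bromophenyl on the triazole. In a functional assay on SMMC-7721 cells (Homo sapiens) for cytotoxicity, read by MTT assay, with a stated time of 4 days (on this read-out higher numbers stand for weaker inhibition and lower numbers for stronger inhibition), compound 1 gives 4320 nM, the highest of the two numbers reported, the nearest neighbour being compound 3 `C=C1C(=O)[C@]23C[C@@]1(O)CC[C@H]2c1ccc(O)c(C)c1[C@@H]3Cn1cc(-c2ccc(Br)cc2)nn1`, which gives 1300 nM in this assay. Going by the values given here, the single measured step, a 3.3-fold lower number from compound 1 to compound 3 (0.52 log units; beyond the scatter), thus concerns the phenolic oxygen and not the aryl group on the triazole. Compound 2 `Cc1c(O)ccc2c1[C@H](Cn1cc(-c3ccc(C(F)(F)F)cc3)nn1)[C@@]13CC(=O)[C@@](C)(CC[C@@H]21)C3`, built on a different core with a trifluoromethyl-bearing aryl, reaches only a limit of > 20000 nM in this assay, as recorded in the limit of > 20000 nM in this assay, at which 1 of the 3 values shown sits.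

Compound 4 `C=C1C(=O)[C@]23C[C@@]1(O)CC[C@H]2c1ccc(OS(=O)(=O)c2ccc(C)cc2)c(C)c1[C@@H]3Cn1cc(-c2ccc(OC)cc2)nn1` keeps the sulfonylated oxygen of compound 1 and differs from it only in the aryl group: methoxy in place of bromo on an aromatic carbon. Among the compounds with values here, no measured pair in this set changes the aryl substituent alone, so the step has no direct precedent; the one known step, from the sulfonyl to the free phenol, bears on another part of the molecule. The expectation is therefore that compound 4 changes by a 1.4-fold higher number from compound 1 to compound 4 (0.14 log units; within the scatter), a step within the usual scatter. Compound 4 is estimated to give 6000 nM in this assay, with a range from 2500 nM to 15000 nM.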

Compound 4, half-maximal inhibitory concentration: 1720 nM
Compound 4: the middle estimate sits 3.5-fold (0.54 log units) above what was measured, and the stated range ends above it.
By their numbers in this assay, from the lowest: compounds 3 and 4 (each within the scatter of the next); then compound 1. At a limit, above all of these: compound 2.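

The aryl group on the triazole proves to be a position that responds in this assay: with the sulfonylated oxygen held fixed, the change from 4-bromophenyl to 4-methoxyphenyl gives a 2.5-fold lower number from compound 1 to compound 4 (0.40 log units; beyond the scatter). Going by these compounds alone, until now the only measured step, a 3.3-fold lower number from compound 1 to compound 3 (0.52 log units; beyond the scatter), concerned the phenolic oxygen, so this is the first sign that the far end of the molecule also moves the number, and that a change there need not weaken the result on this read-out. What in the exchange of bromo for methoxy lies behind the step is something the measurements shown do not tell.

The step is seen only with the (4-methylphenyl)sulfonyl group on the oxygen, so the compounds shown leave open whether methoxy in place of bromo would move the number in the same direction on the free phenol of compound 3. They also leave open how an amine, a carboxylic acid or a longer alkoxy chain on the same aromatic carbon, para to a large group, would compare with bromo and methoxy in this assay.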